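A Methyl Added to the Ring Amine of Compound 2

The source may hold more compounds than are shown below. What is called first, only, known or untested is meant among the compounds shown, and "the series" means these compounds.

Of the compounds shown here, two have so far been measured in a functional assay on Bel-7402 cells (Homo sapiens) for cytotoxicity, read by MTT assay, with a stated time of 48 h; on this read-out lower numbers stand for stronger inhibition and higher numbers for weaker inhibition. Compound 1 `CCn1cc(-c2nc3ccccc3o2)c(=O)c2cc(F)c(N3CCN(C)CC3)cc21` gives 2000 nM in this assay. Compound 2 `CCn1cc(-c2nc3ccccc3s2)c(=O)c2cc(F)c(N3CCNCC3)cc21` gives 24300 nM, the higher of the two numbers, and its gap to compound 1 lies beyond the usual scatter. Compound 1 and compound 2 differ in more than one place, so the separate contribution of each difference is not resolved. Compound 3 `CCn1cc(-c2nc3ccccc3s2)c(=O)c2cc(F)c(N3CCN(C)CC3)cc21` has not yet been measured. It differs from compound 2 in one place: methyl in place of hydrogen on an amine nitrogen in a ring. For the measured compounds named here, no measured pair isolates this change, so the expectation rests on compound 2 and on compound 1, which also carries the 4-methylpiperazin-1-yl group and gives 2000 nM. A downward step is expected, a 3.0-fold lower number from compound 2 to compound 3 (0.48 log units; beyond the scatter), moderate in size and probably beyond the scatter. Compound 3 is accordingly estimated at 8000 nM, within a range from 2500 nM to 25000 nM.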

Compound 3, half-maximal inhibitory concentration: 24000 nM
Estimate against measurement, compound 3: 3.0-fold (0.48 log units) below, within the range that was stated.
By their numbers in this assay, from the lowest: compound 1; then compounds 3 and 2 (each within the scatter of the next).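

In this assay, the methyl on the ring amine is now isolated by a 1.0-fold lower number from compound 2 to compound 3 (0.01 log units; within the scatter) and so, with 1,3-benzothiazol-2-yl in place, piperazin-1-yl and 4-methylpiperazin-1-yl cannot be told apart at this position. For the compounds shown here, the change on the aromatic carbon, 1,3-benzothiazol-2-yl in place of 1,3-benzoxazol-2-yl, is also isolated for the first time, and it gives a 12-fold higher number from compound 1 to compound 3 (1.08 log units; beyond the scatter) with the 4-methylpiperazin-1-yl group held constant, a large step where the methyl step is not. Nothing measured here explains the size of either step.

The compounds shown leave open whether the methyl step would read the same with 1,3-benzoxazol-2-yl on the aromatic carbon. They also leave open what an ethyl group or a longer chain on the ring amine nitrogen would give.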